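Urea in place of amide on a thiazolopiperidine alkyne core

The source may hold more compounds than are shown below. What is called first, only, known or untested is meant among the compounds shown, and "the series" means these compounds.

Measured compounds:
compound 1 `Fc1cccc(C#Cc2nc3c(s2)CN(C2CCC2)CC3)c1` — > 10000 nM
compound 2 `COC1CC(C(=O)N2CCc3nc(C#Cc4ccccc4)sc3C2)C1` — 640 nM

Of the compounds shown here, two have been measured in an assay on HEK293 cells for positive allosteric modulation of metabotropic glutamate receptor 5 (Homo sapiens), read by FLIPR, with a stated time of 1 h; on this read-out higher numbers stand for an effect only at larger amounts of compound and lower numbers for an effect already at smaller amounts. Compound 1 is reported only at a limit of this assay, > 10000 nM, which is not a number; this is the point noted as the limit of > 10000 nM in this assay, at which 1 of the 2 values shown sits. Compound 2 gives 640 nM in this assay. Among the two values shown, that of compound 2 is the only one that is a number. For the measured compounds named here, no pair of measured compounds differs in one place, so no measured step is available.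

Compound 3 `O=C(N1CCCC1)N1CCc2nc(C#Cc3ccccc3)sc2C1` has not yet been measured in this assay. It differs from compound 2 in one place: pyrrolidin-1-yl in place of 3-methoxycyclobutyl on a carbonyl carbon. Whether pyrrolidin-1-yl on the carbonyl carbon, in place of 3-methoxycyclobutyl, helps or hurts is not shown by any measured pair here. The step from compound 2 to compound 3 is therefore expected to be small, a 2.3-fold higher number from compound 2 to compound 3 (0.37 log units; beyond the scatter), leaning toward a weaker effect but possibly within the scatter. Compound 3 is expected to give about 1500 nM in this assay, with a range from 400 nM to 6000 nM.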

Compound 3, half-maximal effective concentration: 9.8 nM
Compound 3: middle estimate off by 150-fold (2.18 log units), on the high side, outside the stated range (below it).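

For the compounds shown here, the change to pyrrolidin-1-yl in place of 3-methoxycyclobutyl on the carbonyl carbon gives a 65-fold lower number from compound 2 to compound 3 (1.81 log units; beyond the scatter) in this assay, the first measured step, and it shows that this one position can move the read-out far beyond the usual scatter. It also shows that the hydrogen-bond acceptor counted on 3-methoxycyclobutyl is not required at this position for a low number, as the pyrrolidin-1-yl group that enters has none and the ring now reaches the carbonyl carbon through nitrogen rather than carbon. Nothing measured here accounts for the size of this step.

As far as these compounds go, the ring and the atom bonded to the carbonyl carbon changed together, so it remains open which of them matters; a cyclopentyl group on the carbonyl carbon, or a piperidin-1-yl or dimethylamino group there, would help to separate the two. Also open, from the compounds shown here alone, is whether a fluorine on the phenyl ring, as carried by compound 1, would be tolerated together with the pyrrolidin-1-yl carbonyl.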